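A few compounds are considered here, and "the series" means these few. Any claim that something is new, unique, unknown or untested is made for them only; others in the source may bear on it.

Three compounds that share one core have numbers in a functional assay on PC-3 cells (Homo sapiens) for cytotoxicity; on this read-out lower numbers stand for an effect already at smaller amounts and higher numbers for an effect only at larger amounts of compound: compound 1 `COC1=C(C)C(=O)/C(=C(O)/C=C/c2ccc(OC)cc2)C(=O)C1(C)C`, with a 4-methoxyphenyl group, compound 2 `COC1=C(C)C(=O)/C(=C(O)/C=C/c2ccc(F)cc2)C(=O)C1(C)C`, with a 4-fluorophenyl group, and compound 3 `COC1=C(C)C(=O)/C(=C(O)/C=C/c2ccccc2C)C(=O)C1(C)C`, with a 2-methylphenyl group. In this assay compound 1 gives 18.2 ug/mL, compound 2 gives 7.2 ug/mL and compound 3 gives 9 ug/mL. Compound 3 cannot be told apart from compound 2, with a 1.3-fold higher number from compound 2 to compound 3 (0.10 log units; within the scatter). Compound 1 stands apart from both, with a 2.5-fold lower number from compound 1 to compound 2 (0.40 log units; beyond the scatter) and a 2.0-fold lower number from compound 1 to compound 3 (0.31 log units; beyond the scatter).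

Compound 4 `COC1=C(C)C(=O)/C(=C(O)/C=C/c2c(C)cccc2C)C(=O)C1(C)C` keeps the shared core and turns the 2-methylphenyl group into a 2,6-dimethylphenyl group: methyl in place of hydrogen on an aromatic carbon. The new methyl stands on an aromatic carbon, ortho to a large group and meta to a methyl group. For the measured compounds named here, no measured step adds a methyl to this ring, so the evidence is only indirect. The exchanges on the aromatic group of these three compounds stayed modest, the largest being the step of compound 1 to compound 2 shown above, and the step to compound 3 from compound 2 stayed within the scatter. No step beyond the scatter is therefore expected in this assay, and no firm direction can be given. The expected change is a 1.1-fold lower number from compound 3 to compound 4 (0.05 log units; within the scatter). Compound 4 is estimated at 8 ug/mL, with an expected range from 4 ug/mL to 16 ug/mL.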

Compound 4, concentration for half-maximal effect: 17.1 ug/mL
Compound 4: middle estimate off by 2.1-fold (0.33 log units), on the low side, and the stated range ends below it.
By their numbers in this assay, from the lowest: compounds 2, 3, 4 and 1 (each within the scatter of the next, the first and the last beyond it).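

In this assay, for the compounds shown here, the step from the 2-methylphenyl to the 2,6-dimethylphenyl group gives the first direct reading for a methyl on this aromatic carbon, ortho to a large group and meta to a methyl group, and with a 1.9-fold higher number from compound 3 to compound 4 (0.28 log units; within the scatter) it cannot be called a real change by itself. The same group does separate the compounds at a greater distance: the 4-fluorophenyl compound stands apart, with a 2.4-fold higher number from compound 2 to compound 4 (0.38 log units; beyond the scatter), whereas the 4-methoxyphenyl compound cannot be told apart, with a 1.1-fold lower number from compound 1 to compound 4 (0.03 log units; within the scatter), so compound 3 lies within the scatter of compound 4 and of compound 2 although those two differ beyond it. Nothing measured here bears on what lies behind this result.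

The compounds shown leave open how a different group on this same aromatic carbon would read, such as a chlorine atom, a hydroxyl or an amine, and whether a 2,6-dichlorophenyl group would fall with compound 4 or with compound 2. They also leave open whether a still larger group here, such as an ethyl or an isopropyl, would take the number clearly beyond that of compound 3.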